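The source may hold more compounds than are shown below. What is called first, only, known or untested is meant among the compounds shown, and "the series" means these compounds.

Measured in a functional assay on brain (Rattus norvegicus, strain Wistar) for inhibition; on this read-out lower numbers stand for stronger inhibition and higher numbers for weaker inhibition:
- compound 1 `COc1ccc(-c2c(C)[nH]c(=O)n2C)cc1` gives 147000 nM
- compound 2 `COc1ccc(-c2c(C)[nH]c(=O)n2C2CCCCC2)cc1` gives 20400 nM
- compound 3 `CCCCCCCCCCCCCCCCCCOc1ccc(-c2c(C)[nH]c(=O)n2C2CCCCC2)cc1` gives only a limit of the assay, > 100000 nM

Compound 2 holds the lowest of the two numbers that are numbers. For the measured compounds named here, the only step measured so far runs to it: a 7.2-fold lower number from compound 1 to compound 2 (0.86 log units; beyond the scatter), a change of cyclohexyl in place of methyl on an aromatic nitrogen. Going by the values given here, compound 3 sits at the limit of > 100000 nM in this assay, at which 1 of the 3 values shown sits; it is a limit and not a number, so it offers no step to build on.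

Compound 4 `Cc1[nH]c(=O)n(C2CCCCC2)c1-c1ccc(-c2ccccc2)cc1` is the next compound, and it differs from compound 2 in one place: phenyl in place of methoxy on an aromatic carbon

Among the compounds with values here, no measured step bears on this change. Within the data shown here, the one step that is known, from compound 1 to compound 2, alters the group on the aromatic nitrogen, not the group on the aromatic carbon where phenyl replaces methoxy. The change is therefore judged without a precedent, and in this assay a step of no more than the usual scatter is expected, in either direction, with wide uncertainty.

Compound 4 is expected to give 15000 nM, with a range from 3000 nM to 80000 nM. That estimate means an expected step of a 1.4-fold lower number from compound 2 to compound 4 (0.13 log units; within the scatter).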

Compound 4, half-maximal inhibitory concentration: 10900 nM
For compound 4 the middle estimate is 1.4-fold (0.14 log units) above the measured one; low and high end bracket the measured number.
By their numbers in this assay, from the lowest: compounds 4 and 2 (each within the scatter of the next); then compound 1.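

On the aromatic carbon para to a large group, a phenyl with its six heavy atoms can stand in place of a methoxy with two, and the result in this assay stays within the usual scatter (a 1.9-fold lower number from compound 2 to compound 4 (0.27 log units; within the scatter)). For this pair, the added ring does not cost activity, and the hydrogen-bond acceptor that methoxy carries is not needed to keep the number where it is, since phenyl has none. Compound 3, which carries a long chain on the oxygen at this same place, gives only a limit and not a number, so it cannot be set against this step: the limit of > 100000 nM in this assay, at which 1 of the 4 values shown sits.

Nothing shown gives a cause for what phenyl does here, so the result can be described but not explained. On these data alone, it remains open whether an amine, a carboxylic acid or a short chain such as ethoxy at this place would also keep the number, and whether phenyl would behave the same way with methyl rather than cyclohexyl on the aromatic nitrogen.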